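Halogen swap on the anilide ring of the thioether series

A few compounds are considered here, and "the series" means these few. Any claim that something is new, unique, unknown or untested is made for them only; others in the source may bear on it.

Of the compounds shown here, three sharing one core have numbers so far. Compound 1 `CCCOc1ccc(NC(=O)CCCCCCCSc2nnc(Cc3nn(C)c(=O)c4ccccc34)n2C)cc1` gives 40000 nM in an assay on cells for inhibition of IL15-IL15 receptor (Homo sapiens), read by AlphaScreen, with stated times of 30 min and 1 h; a higher number here means a weaker inhibitor, a lower number a stronger inhibitor. Compound 2 `CC(C)Oc1ccc(NC(=O)CCCCCCCSc2nnc(Cc3nn(C)c(=O)c4ccccc34)n2C)cc1` gives 93000 nM in this assay, and compound 3 `Cn1c(Cc2nn(C)c(=O)c3ccccc23)nnc1SCCCCCCCC(=O)Nc1ccc(Br)cc1Br` gives 92000 nM. Compound 3 thus sits in the weaker part of the set: its number is indistinguishable from that of compound 2, while a 2.3-fold higher number from compound 1 to compound 3 (0.36 log units; beyond the scatter) marks a modest loss against compound 1.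

Compound 4 `Cn1c(Cc2nn(C)c(=O)c3ccccc23)nnc1SCCCCCCCC(=O)Nc1ccc(F)cc1F` differs from compound 3 only at the anilide ring: 2,4-difluorophenyl in place of 2,4-dibromophenyl on an amide-type nitrogen. Among the compounds with values here, no measured pair exchanges one halogen for another on this ring. The steps that touch the same position are a 2.3-fold higher number from compound 1 to compound 3 (0.36 log units; beyond the scatter) and a 1.0-fold lower number from compound 2 to compound 3 (0.00 log units; within the scatter), and both tell that changing the substituents on this ring moves the number little, within or just beyond the scatter. The number for compound 4 is therefore expected to stay close to that of compound 3, with a 1.1-fold higher number from compound 3 to compound 4 (0.04 log units; within the scatter) as the anticipated step. The estimate for compound 4 is 100000 nM, with a range from 40000 nM to 250000 nM; a limit reading cannot be excluded given how weak the nearest compounds are.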

Compound 4, half-maximal inhibitory concentration: 110000 nM
Estimate against measurement, compound 4: 1.1-fold (0.04 log units) below; the range from low to high includes it.
By their numbers in this assay, from the lowest: compound 1; then compounds 3, 2 and 4 (each within the scatter of the next).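

Within the data shown here, the one pair in which a halogen is exchanged for another on this ring gives a 1.2-fold higher number from compound 3 to compound 4 (0.08 log units; within the scatter) in this assay, so 2,4-difluorophenyl and 2,4-dibromophenyl on the amide-type nitrogen cannot be told apart here. The 2,4-difluorophenyl anilide also cannot be told from the 4-isopropoxyphenyl anilide, with a 1.2-fold higher number from compound 2 to compound 4 (0.07 log units; within the scatter) as the step, while a 2.8-fold higher number from compound 1 to compound 4 (0.44 log units; beyond the scatter) is a modest step that leaves only the 4-propoxyphenyl anilide, compound 1, apart from compound 4. Nothing available bears on why these anilides read as they do.

Still open, on these data alone, is whether any group on this ring, such as an amine or a carboxylic acid, moves the number further than these halogen and alkoxy groups do. The compounds shown also leave open what a shorter chain between the amide and the sulfur would do.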